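Fluoro to Hydrogen on the Aryl Ring: Compound 4 Expected

The source may report more compounds than this note shows. Statements on the series, on what has been measured and on what is new or still open speak of the compounds shown alone.

Measured so far in an ADME assay on NIH3T3 cells (Mus musculus) for cytotoxicity, read by MTT assay, with a stated time of 24 h; a lower number here means a stronger inhibitor, a higher number a weaker inhibitor:
compound 1 `O=C(CSc1nnnn1-c1ccccc1)N/N=c1/scc(-c2ccccc2)n1-c1ccccc1` gives 417 ug/mL;
compound 2 `COc1ccc(-c2cs/c(=N/NC(=O)CSc3nncn3C)n2-c2ccccc2)cc1` gives 167 ug/mL;
compound 3 `Cn1cnnc1SCC(=O)N/N=c1/scc(-c2ccc(F)cc2)n1-c1ccccc1` gives 65 ug/mL.

Compound 3 stands at the lowest number of the three in this assay, with compound 2 the nearest and compound 1 the furthest. Going by the values given here, the one measured single-point step, a 2.6-fold lower number from compound 2 to compound 3 (0.41 log units; beyond the scatter), exchanges one substituent for another and does not directly address the removal of a substituent. Compound 4 `Cn1cnnc1SCC(=O)N/N=c1/scc(-c2ccccc2)n1-c1ccccc1` differs from compound 3 by hydrogen in place of fluoro on an aromatic carbon. Among the compounds with values here, no measured step bears directly on this change, so only a small shift toward a higher number is expected, a 1.5-fold higher number from compound 3 to compound 4 (0.19 log units; within the scatter). Compound 4 is therefore estimated at 100 ug/mL in this assay, within a range of 40 ug/mL to 250 ug/mL.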

Compound 4, half-maximal inhibitory concentration: 217 ug/mL
Estimate against measurement, compound 4: 2.2-fold (0.34 log units) below; the measured number falls inside the stated range.
By their numbers in this assay, from the lowest: compound 3; then compounds 2, 4 and 1 (each within the scatter of the next, the first and the last beyond it).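

In this assay, the change from 4-fluorophenyl to phenyl gives a 3.3-fold higher number from compound 3 to compound 4 (0.52 log units; beyond the scatter), so on this aromatic carbon the fluoro, and not only its exchange for methoxy, sets compound 3 apart. Hydrogen and methoxy at this place are not told apart, with a 1.3-fold higher number from compound 2 to compound 4 (0.11 log units; within the scatter), and the change on the sulfur, 4-methyl-4H-1,2,4-triazol-3-yl in place of 1-phenyl-1H-tetrazol-5-yl, also stays inside the scatter, with a 1.9-fold lower number from compound 1 to compound 4 (0.28 log units; within the scatter). Nothing shown gives a reason for the fluoro step.

Going by these compounds, whether chloro or an amine on this aromatic carbon would read like fluoro or like hydrogen stays open. So does whether the fluoro step holds with 1-phenyl-1H-tetrazol-5-yl on the sulfur.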